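The source may report more compounds than this note shows. Statements on the series, on what has been measured and on what is new or still open speak of the compounds shown alone.

Measured so far:
compound 1 `CC1CCN(CCCOc2ccc3c(c2)C(=O)N(C)CC3)CC1`: 32 nM
compound 2 `CC1CCCN1CCCOc1ccc2c(c1)C(=O)N(C)CC2`: 26 nM
compound 3 `CCN1CCN(CCCOc2ccc3c(c2)C(=O)N(C)CC3)CC1`: 1100 nM

In an assay on cerebellum for displacement of a labelled ligand from histamine H1 receptor (Cavia porcellus), read by scintillation counting, with a stated time of 60 min (a higher number here means a weaker inhibitor, a lower number a stronger inhibitor), compound 3 stands highest of the three numbers, well beyond the scatter from both others. Compound 4 `CCN(CC)CCCOc1ccc2c(c1)C(=O)N(C)CC2` differs from compound 3 by diethylamino in place of 4-ethylpiperazin-1-yl on a saturated chain carbon, three bonds along the chain from an oxygen on an aromatic ring. Within the data shown here, the steps that bear on this change are a 34-fold higher number from compound 1 to compound 3 (1.54 log units; beyond the scatter) and a 42-fold higher number from compound 2 to compound 3 (1.63 log units; beyond the scatter); both bring in the 4-ethylpiperazin-1-yl of compound 3 and both give a large rise. Compound 4 removes that same group again, so a large fall in this assay is expected: a 22-fold lower number from compound 3 to compound 4 (1.34 log units; beyond the scatter). No open-chain amine has been measured, which leaves the exact size uncertain. Compound 4 is estimated at 50 nM, with a range from 15 nM to 200 nM.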

Compound 4, inhibition constant: 542 nM
Estimate against measurement, compound 4: 11-fold (1.04 log units) below, and the stated range ends below it.
By their numbers in this assay, from the lowest: compounds 2 and 1 (each within the scatter of the next); then compound 4; then compound 3.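

In this assay, the open-chain diethylamino gives only a 2.0-fold lower number from compound 3 to compound 4 (0.31 log units; beyond the scatter), while a 21-fold higher number from compound 2 to compound 4 (1.32 log units; beyond the scatter) and a 17-fold higher number from compound 1 to compound 4 (1.23 log units; beyond the scatter). Among these compounds, then, losing the 4-ethylpiperazin-1-yl is not enough to give a low number, and the one amine here without a ring stays well above the two ring amines that carry a single nitrogen. Nothing measured here explains this. Still open, as far as these compounds go, is whether a smaller open-chain amine such as dimethylamino, or an unsubstituted piperidine or pyrrolidine, would fall nearer compound 1 or compound 4.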